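From a methoxyphenyl to a nitrophenyl amine on one core

A few compounds are considered here, and "the series" means these few. Any claim that something is new, unique, unknown or untested is made for them only; others in the source may bear on it.

Of the compounds shown here, three built on one shared core have been tested in a functional assay on MDA-MB-231 cells (Homo sapiens) for cytotoxicity, read by MTT assay, with a stated time of 72 h; a lower number here means a stronger inhibitor, a higher number a weaker inhibitor. Compound 1 `CCCCCCCCNc1nc(SCc2ccc(C(F)(F)F)cc2)nc2ccccc12` gives 22300 nM. Compound 2 `CCCCCCCCCCCCCCNc1nc(SCc2ccc(C(F)(F)F)cc2)nc2ccccc12` reaches only the limit of the assay, > 50000 nM. Compound 3 `COc1ccccc1Nc1nc(SCc2ccc(C(F)(F)F)cc2)nc2ccccc12` likewise gives only the assay limit, > 50000 nM. Among the measured compounds shown here, both measured steps, an at least 2.2-fold higher number from compound 1 to compound 2 (0.35 log units; beyond the scatter) and an at least 2.2-fold higher number from compound 1 to compound 3 (0.35 log units; beyond the scatter), therefore run from the single true number to the limit, which is where compound 3 stands, as noted by the limit of > 50000 nM in this assay, at which 2 of the 3 values shown sit.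

Compound 4 `O=[N+]([O-])c1cccc(Nc2nc(SCc3ccc(C(F)(F)F)cc3)nc3ccccc23)c1` differs from compound 3 by 3-nitrophenyl in place of 2-methoxyphenyl on a nitrogen on an aromatic ring. Of the measured steps only the one from compound 1 to compound 3 touches the group on this nitrogen, and it gave at least a modest loss; no step compares two aryl groups in that position, so the direction of the present change is not shown. Resting on the limit seen for compound 3, he expects the step from compound 3 to compound 4 to be a step that the limit leaves unreadable from compound 3 to compound 4, not beyond the scatter. He estimates compound 4 at 60000 nM, between 20000 nM and 200000 nM.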

Compound 4, half-maximal inhibitory concentration: 31500 nM
For compound 4 the middle estimate is 1.9-fold (0.28 log units) above the measured one; the range from low to high includes it.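

With 3-nitrophenyl, an aryl group on this nitrogen gives a true number in this assay, so the limit seen with 2-methoxyphenyl does not hold for every aryl group. The exchange for octyl reads a 1.4-fold higher number from compound 1 to compound 4 (0.15 log units; within the scatter) and so does not tell this aryl group from the chain. The exchange for 2-methoxyphenyl reads an at least 1.5-fold lower number from compound 3 to compound 4 (0.20 log units; that floor lies within the scatter) and gives only a floor and no size, as compound 3 carries only a limit: the limit of > 50000 nM in this assay, at which 2 of the 4 values shown sit.

The compounds shown leave open how a phenyl ring carrying an amine or a carboxylic acid in place of the nitro group would read on this nitrogen. They also leave open whether a chain shorter than octyl would give a number beyond the scatter from compound 1.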